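Swapping the Amide Substituent: From Compound 3 to Compound 4

The source may report more compounds than this note shows. Statements on the series, on what has been measured and on what is new or still open speak of the compounds shown alone.

Measured compounds:
Compound 1, `CNS(=O)(=O)c1ccccc1Nc1cc(-c2ccc3ccn(C)c3c2)c2nccnc2c1`: > 100000 nM
Compound 2, `CN(C)S(=O)(=O)c1ccccc1Nc1cc(-c2ccc3ccn(C)c3c2)c2nccnc2c1`: 7670 nM
Compound 3, `CC(=O)N1CCC(NC(=O)c2ccncc2Nc2cc(-c3ccc4ccn(C)c4c3)c3nccnc3c2)CC1`: 31300 nM

All three were tested in an assay on lysate for inhibition of 6-phosphofructo-2-kinase/fructose-2,6-bisphosphatase 3 (Homo sapiens), with stated times of 0.5 min and 45 min; on this read-out lower numbers stand for stronger inhibition and higher numbers for weaker inhibition. For compound 1 the result is only a limit of the assay, (the limit of > 100000 nM in this assay, at which 1 of the 3 values shown sits), and not a number. Among the two values reported as numbers, compound 3 stands highest; compound 2 gives the lower number, and the gap between them lies beyond the scatter.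

Compound 4, `CN1CCC(CNC(=O)c2ccncc2Nc2cc(-c3ccc4ccn(C)c4c3)c3nccnc3c2)C1`, has not yet been measured. It differs from compound 3 in one place: (1-methylpyrrolidin-3-yl)methyl in place of 1-acetylpiperidin-4-yl on an amide-type nitrogen.

For the measured compounds named here, the only measured step that exists in this set, an at least 13-fold lower number from compound 1 to compound 2 (1.11 log units; beyond the scatter), concerns a sulfonamide nitrogen and a methyl, not the amide-type nitrogen that is changed here. The data hold no step in which the group on that nitrogen is varied, so nothing shown speaks directly to the move from compound 3 to compound 4. On that basis no step beyond the scatter is expected in this assay, in either direction.

The estimate for compound 4 is therefore 30000 nM, within a range from 9000 nM to 100000 nM, which corresponds to an expected step of a 1.0-fold lower number from compound 3 to compound 4 (0.02 log units; within the scatter).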

Compound 4, half-maximal inhibitory concentration: 24000 nM
Estimate against measurement, compound 4: 1.3-fold (0.10 log units) above; the range from low to high includes it.
By their numbers in this assay, from the lowest: compound 2; then compounds 4 and 3 (each within the scatter of the next). At a limit, above all of these: compound 1.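

In this assay, for the compounds shown here, the group on the amide-type nitrogen is varied for the first time, and (1-methylpyrrolidin-3-yl)methyl in place of 1-acetylpiperidin-4-yl gives a 1.3-fold lower number from compound 3 to compound 4 (0.12 log units; within the scatter). At this position, then, the six-membered non-aromatic ring can give way to a five-membered one, and the acetyl carbonyl can go, with no change that stands clear of the scatter, so this exchange neither recovers nor loses measurable inhibition. None of the evidence at hand bears on why the two compounds read alike.

The exchange alters ring size, the group on the ring nitrogen and the link to the amide-type nitrogen all at once, so the compounds shown cannot say whether each alteration is silent alone or whether separate effects offset one another. They also leave open what would happen on that nitrogen with a carboxylic acid, a primary amine, a longer unbranched alkyl chain or a simple methyl, groups whose values could show whether this position responds at all.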